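This account rests on a few compounds, and the source may have more. Where it says the series, first, only, none or still open, it means among the compounds named here.

The compounds measured so far:

Compound 1, `COc1ccc(CNc2nc([SeH])nc3ccccc23)cc1`: > 100000 nM
Compound 2, `[SeH]c1nc(NCc2ccccc2)c2cccnc2n1`: > 100000 nM

Both readings come from a functional assay on HT-29 cells (Homo sapiens) for cytotoxicity, read by MTT assay, with a stated time of 72 h; a lower number here means that less compound is tolerated, a higher number that more compound is tolerated. For compound 1 the reading > 100000 nM is a limit of the assay, not a number. For compound 2 the reading > 100000 nM is likewise a limit, not a number. Within the data shown here, compound 2 therefore stands only at a limit in this assay, and the one other value shown beside it is a limit as well, which is the situation summed up by the limit of > 100000 nM in this assay, at which 2 of the 2 values shown sit. Among the measured compounds shown here, no step between two measured compounds exists here, so nothing has yet been measured about how a change in structure moves this read-out.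

Compound 3 is `CSc1nc(NCc2ccccc2)c2cccnc2n1`. It differs from compound 2 in this way: a group of 2 heavy atoms (1 carbon, 1 sulfur; no ring) in place of one selenium atom, on an aromatic carbon. For the measured compounds named here, with no measured step to lean on, the expectation for this assay is no movement beyond the scatter, and the expected step is a step that the limit leaves unreadable from compound 2 to compound 3. Compound 3 is thus expected to give about 150000 nM, within a range from 40000 nM to 600000 nM, most probably reported again only as a limit.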

Compound 3, concentration lethal to 50% of the cells: > 100000 nM
Compound 3: a limit, no number; the forecaster's own chance of this, stated with the estimate: 80%; the middle value does not contradict the limit.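

Compound 3 gives > 100000 nM, which is a limit and not a number, so no step can be read from compound 2 to compound 3. The compounds shown leave open how methylsulfanyl in place of selenium moves this read-out, and which structural change would yield an actual number, because all of them share one limit: the limit of > 100000 nM in this assay, at which 3 of the 3 values shown sit.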